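The source may report more compounds than this note shows. Statements on the series, on what has been measured and on what is new or still open speak of the compounds shown alone.

Two compounds of the series have a measurement so far. Compound 1 `CCOC(=O)C1CCN(Cn2nc(C(C)c3ccc(CC(C)C)cc3)oc2=S)CC1` carries an ester on a saturated six-membered ring as its amine part; in a functional assay on the whole organism (strain Wister albino) for inhibition, with Rattus norvegicus as the target, read by paw edema, with stated times of 30 min and 3 h, at a dose of 10 mg/kg by the oral route (on this read-out higher numbers stand for more inhibition at the one dose given (going by the name of the read-out) and lower numbers for less inhibition), compound 1 gives 73.9%. Compound 2 `CC(C)Cc1ccc(C(C)c2nn(CN3CCN(c4ccc(Cl)cc4)CC3)c(=S)o2)cc1` carries a 4-chlorophenyl on a piperazine in place of that ester ring; in this assay compound 2 gives 76.6%. Compound 2 holds the higher of the two numbers, but the gap to compound 1 lies within the scatter of repeated measurements, so the two readings cannot be told apart.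

Compound 3 `CC(C)Cc1ccc(C(C)c2nn(CN3CCN(c4ccc([N+](=O)[O-])cc4)CC3)c(=S)o2)cc1` is the next member awaiting measurement. It differs from compound 2 in one place: nitro in place of chloro on an aromatic carbon. Going by the values given here, no step between measured compounds touches this position, so there is nothing that sets a direction for the change. The expectation for compound 3 is therefore a step of a number 1.6 percentage points lower from compound 2 to compound 3 (within the scatter) not beyond the scatter. Compound 3 is estimated at 75% in this assay, with a range from 62% to 86%.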

Compound 3, a percentage reported as inhibition, in the whole organism at one dose (the size of the read-out at that dose, not a potency): 75.1%
Compound 3: middle estimate off by 0.1 percentage points, on the low side; the range from low to high includes it.
By their numbers in this assay, from the lowest: compounds 1, 3 and 2 (each within the scatter of the next).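

In this assay, going by these compounds alone, nitro in place of chloro on the aromatic carbon para to a large group gives a number 1.5 percentage points lower from compound 2 to compound 3 (within the scatter), the first step that touches this position. The 4-chlorophenyl and 4-nitrophenyl compounds therefore cannot be told apart at this one dose, even though the exchange takes the substituent from 1 heavy atom and 0 hydrogen-bond acceptors to 3 heavy atoms and 2 hydrogen-bond acceptors. No measurement shown here bears on why the two readings fall within the scatter of each other.

As far as these compounds go, this single pair of substituents does not show whether the position is insensitive to change in general, so it remains open whether an amino group, a carboxylic acid or a methoxy group on the same aromatic carbon would give a step beyond the scatter. The size of the read-out at one dose also leaves open whether compound 2 and compound 3 would still read alike at other doses.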